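A Chloro Group Added to Compound 1

The source may report more compounds than this note shows. Statements on the series, on what has been measured and on what is new or still open speak of the compounds shown alone.

Measured in an ADME assay on MRC5 cells (Homo sapiens) for cytotoxicity, read by MTT assay, with a stated time of 48 h; on this read-out lower numbers stand for stronger inhibition and higher numbers for weaker inhibition:
- Compound 1 `O=C1Nc2ccccc2C1(c1c(-c2ccccc2)[nH]c2ccccc12)c1c(-c2ccccc2)[nH]c2ccccc12`: > 100000 nM
- Compound 2 `COC(=O)c1ccc2[nH]cc(C3(c4c[nH]c5ccc(C(=O)OC)cc45)C(=O)Nc4ccccc43)c2c1`: > 100000 nM
- Compound 3 `O=C1Nc2ccc(Cl)cc2C1(c1c[nH]c2ccc(Br)cc12)c1c[nH]c2ccc(Br)cc12`: > 100000 nM

None of these entries is an exact number. Compound 1 stands at > 100000 nM, which is a limit of the assay. The other two entries are limits as well, so the whole set shows one picture: the limit of > 100000 nM in this assay, at which 3 of the 3 values shown sit.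

Compound 4 `O=C1Nc2ccc(Cl)cc2C1(c1c(-c2ccccc2)[nH]c2ccccc12)c1c(-c2ccccc2)[nH]c2ccccc12` keeps the core of compound 1 and takes a chloro in place of hydrogen on an aromatic carbon. Going by the values given here, no two measured compounds differ in just one place, so no measured step shows what this change does in this assay. Compound 3 also carries a chloro group, and its reading of > 100000 nM is a limit too. A change no larger than the usual scatter is therefore expected, with no favoured direction. The estimated step of a number no higher from compound 1 to compound 4 (the limit leaves the size open) reflects this expectation. Compound 4 is expected to read about 100000 nM, with an estimated range of 50000 nM to 200000 nM.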

Compound 4, half-maximal inhibitory concentration: > 100000 nM
Compound 4: no number, only a limit; the forecaster's own chance of this, stated with the estimate: 80%; the middle value sits exactly at the limit.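

Going by these compounds alone, compound 1 and compound 4 are both entered as limits and not as numbers, and no step between them can be read in this assay. The set shows a single picture: the limit of > 100000 nM in this assay, at which 4 of the 4 values shown sit.

The compounds shown leave open whether the chloro group changes the reading at all.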